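Quinoline series: aryl-ether to naphthyl swap and permeability

A few compounds are considered here, and "the series" means these few. Any claim that something is new, unique, unknown or untested is made for them only; others in the source may bear on it.

Compound 3 `COc1ccc(F)cc1CNCCCNc1ccnc2cc(Oc3ccc(Cl)cc3)ccc12` stands highest in an ADME assay for permeability, using PAMPA, with a stated time of 30 min, at pH 7.4 (a higher number here means that the compound crosses the layer faster, a lower number that the compound crosses the layer more slowly), with 317 10^-6 cm/s. Compound 1 `COc1ccc(F)cc1CNCCCNc1ccnc2cc(C3CCCCC3)ccc12` gives 23 10^-6 cm/s in this assay, and compound 2 `CCC(CC)c1ccc2c(NCCCNCc3cc(F)ccc3OC)ccnc2c1` gives 23 10^-6 cm/s. The steps of a 14-fold higher number from compound 1 to compound 3 (1.14 log units; beyond the scatter) and a 14-fold higher number from compound 2 to compound 3 (1.14 log units; beyond the scatter) are large, whereas no change at the digits printed from compound 1 to compound 2 (within the scatter). Compound 4 `COc1ccc(F)cc1CNCCCNc1ccnc2cc(-c3cccc4ccccc34)ccc12` carries the change (naphthalen-1-yl in place of 4-chlorophenoxy on an aromatic carbon). Going by the values given here, no measured step exchanges one aromatic substituent for another at this position, so the steps bearing on it only show that an aromatic group here went with a higher number than either saturated group. A step beyond the scatter is expected, downward, since the oxygen leaves and a second aromatic ring enters without any measured precedent for that. For compound 4 the estimate is 120 10^-6 cm/s, range 30 10^-6 cm/s to 400 10^-6 cm/s, meaning an expected step of a 2.6-fold lower number from compound 3 to compound 4 (0.42 log units; beyond the scatter).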

Compound 4, apparent permeability: 237 10^-6 cm/s
The estimate for compound 4 lay 2.0-fold (0.30 log units) below the measured number; the measured number falls inside the stated range.
By their numbers in this assay, from the lowest: compounds 1 and 2 (each within the scatter of the next); then compounds 4 and 3 (each within the scatter of the next).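

In this assay, one aromatic group now replaces another at this position, giving a 1.3-fold lower number from compound 3 to compound 4 (0.13 log units; within the scatter) and showing that the number can stay at this level without the ether oxygen or the chlorine. The link between an aromatic group and the higher number now rests on a second aromatic group, with a 10-fold higher number from compound 2 to compound 4 (1.01 log units; beyond the scatter) and a 10-fold higher number from compound 1 to compound 4 (1.01 log units; beyond the scatter) against the saturated groups. Nothing available accounts for these numbers. From the compounds shown here alone, how an amine or a carboxylic acid at this position would read remains open, as does the reading for naphthalen-2-yl or unsubstituted phenoxy.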